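The source may report more compounds than this note shows. Statements on the series, on what has been measured and on what is new or still open speak of the compounds shown alone.

Compound 2 `C[C@@H](Cn1ccc(-c2ccc(C#N)c(Cl)c2)n1)Nc1ccncc1` carries a pyridin-4-yl group on its amine nitrogen and, in a functional assay on LNCaP cells (Homo sapiens) for antiproliferative activity, read by CCK-8 assay, with a stated time of 6 days (on this read-out lower numbers stand for stronger inhibition and higher numbers for weaker inhibition), gives 2560 nM. Going by the values given here, only one other compound has been measured: compound 1 `COC(=O)/C=C/C(=O)N[C@@H](C)Cn1ccc(-c2ccc(C#N)c(Cl)c2)n1` gives 2460 nM, and the step of a 1.0-fold higher number from compound 1 to compound 2 (0.02 log units; within the scatter) leaves compound 2 within the scatter of compound 1. Compound 3 `C[C@@H](Cn1ccc(-c2ccc(C#N)c(Cl)c2)n1)Nc1cncnc1` differs from compound 2 by a single change: pyrimidin-5-yl in place of pyridin-4-yl on an amine nitrogen. Among the compounds with values here, the one measured step exchanges a quite different group, so it offers little guidance for this ring swap. The step expected here is a 1.0-fold higher number from compound 2 to compound 3 (0.01 log units; within the scatter), nothing beyond the scatter. Compound 3 is therefore estimated at 2600 nM, with a range from 1300 nM to 5500 nM.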

Compound 3, half-maximal inhibitory concentration: 2070 nM
The estimate for compound 3 lay 1.3-fold (0.10 log units) above the measured number; measured number inside the range.
By their numbers in this assay, from the lowest: compounds 3, 1 and 2 (each within the scatter of the next).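

On this amine nitrogen, the second ring nitrogen of pyrimidin-5-yl changes the reading in this assay by no more than the scatter (a 1.2-fold lower number from compound 2 to compound 3 (0.09 log units; within the scatter)). The step from the open-chain group also stays within the scatter (a 1.2-fold lower number from compound 1 to compound 3 (0.07 log units; within the scatter)), so all three groups at this position read alike. No measurement here explains why these numbers lie so close.

On these data alone, it remains open whether a plain phenyl ring or a carboxylic acid on a longer chain at this nitrogen would move the number beyond the scatter.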